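The compounds below may be only part of what the source reports. "The series", "measured", "known", "first", "only" and "open" are said of these compounds alone.

Compound 1 `Cc1ccccc1-n1cc(CN2C(=O)C[C@@H]3CC[C@@]2(C)C3(C)C)nn1` — in a functional assay on SGC-7901 cells (Homo sapiens) for inhibition, read by MTT assay, with a stated time of 24 h (a higher number here means a weaker inhibitor, a lower number a stronger inhibitor), compound 1 gives 350 nM
Compound 2 `COc1ccccc1-n1cc(CN2C(=O)C[C@@H]3CC[C@@]2(C)C3(C)C)nn1` — compound 2 gives 280 nM
Compound 3 `CC1(C)[C@H]2CC[C@]1(C)N(Cc1cn(-c3ccc(F)cc3)nn1)C(=O)C2` — compound 3 gives 500 nM

Compound 3 carries the highest of the three numbers, but it is not separated from the others: the step of a 1.4-fold higher number from compound 1 to compound 3 (0.15 log units; within the scatter) and the step of a 1.8-fold higher number from compound 2 to compound 3 (0.25 log units; within the scatter) both stay within the scatter, as does the step of a 1.3-fold lower number from compound 1 to compound 2 (0.10 log units; within the scatter) between the two aryl variants that keep the methyl or methoxy. So far the aryl group on the triazole nitrogen has been varied without any change that can be told from noise.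

Compound 4 `CC1(C)[C@H]2CC[C@]1(C)N(Cc1cn(-c3ccc(O)cc3)nn1)C(=O)C2` is the next point. It differs from compound 3 by hydroxy in place of fluoro on an aromatic carbon, on the 4-fluorophenyl that sits on the aromatic nitrogen. Among the compounds with values here, none of the measured steps exchanges a group at this place, so no step bears on it directly; the only guidance is that every aryl change so far has remained within the scatter. On that basis the step of no change at the digits printed from compound 3 to compound 4 (within the scatter) is expected to be small, with no direction that can be called beyond the scatter, and the range is kept wide. For compound 4 in this assay the estimate is 500 nM, between 200 nM and 1300 nM.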

Compound 4, half-maximal inhibitory concentration: 330 nM
The estimate for compound 4 lay 1.5-fold (0.18 log units) above the measured number, and the stated range covers the measured number.
By their numbers in this assay, from the lowest: compounds 2, 4, 1 and 3 (each within the scatter of the next).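

In this assay, within the data shown here, the exchange of fluoro for hydroxy, para to a large group on the six-membered aromatic ring, gives the first step at this place, and a 1.5-fold lower number from compound 3 to compound 4 (0.18 log units; within the scatter) shows that a group with a hydrogen-bond donor and a hydrogen-bond acceptor can stand there without a change that can be told from noise. The comparisons with the other aryl groups read the same way: a 1.2-fold higher number from compound 2 to compound 4 (0.07 log units; within the scatter) and a 1.1-fold lower number from compound 1 to compound 4 (0.03 log units; within the scatter) leave 4-hydroxyphenyl on the aromatic nitrogen inseparable from 2-methoxyphenyl and 2-methylphenyl, so all four compounds form one group in which no aryl variant stands apart and no order among them can be claimed. Nothing at hand gives a reason for the size of these steps.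

Still open, on these data alone, is whether an amine or a carboxylic acid at this same place on the ring would produce a step beyond the scatter, or whether this place stays as flat as the four compounds suggest. Also open, as far as these compounds go, is whether a longer chain on the aromatic nitrogen, in place of the aryl group, would move the number, since every compound here keeps an aryl group there and the same core.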